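Swapping Bromo for Trifluoromethyl on the Outer Ring

The source may report more compounds than this note shows. Statements on the series, on what has been measured and on what is new or still open speak of the compounds shown alone.

Of the compounds shown here, three built on one shared core have been tested in a functional assay on MCF7 cells (Homo sapiens) for antiproliferative activity, read by MTT assay, with a stated time of 48 h; on this read-out lower numbers stand for stronger inhibition and higher numbers for weaker inhibition. Compound 1 `COc1ccc(C2=NN(c3nc(-c4ccc(Br)cc4)cs3)C(c3cccs3)C2)cc1` gives 21200 nM in this assay. Compound 2 `COc1ccc(C2=NN(c3nc(-c4ccc(OC)cc4)cs3)C(c3cccs3)C2)cc1` gives 16200 nM in this assay, and compound 3 `Fc1ccc(C2=NN(c3nc(-c4ccc(Br)cc4)cs3)C(c3cccs3)C2)cc1` gives 8280 nM in this assay. Compound 3 therefore carries the lowest of the three numbers, but its gap to compound 2 lies within the scatter, so only its separation from compound 1 counts as real: the step of a 2.6-fold lower number from compound 1 to compound 3 (0.41 log units; beyond the scatter) was modest yet beyond the scatter, whereas the step of a 1.3-fold lower number from compound 1 to compound 2 (0.12 log units; within the scatter) stayed within it.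

Compound 4 `Fc1ccc(C2=NN(c3nc(-c4ccc(C(F)(F)F)cc4)cs3)C(c3cccs3)C2)cc1` differs from compound 3 in one place: trifluoromethyl in place of bromo on an aromatic carbon. For the measured compounds named here, the only measured step at this same position, the exchange of bromo for methoxy, a 1.3-fold lower number from compound 1 to compound 2 (0.12 log units; within the scatter), left the number essentially unchanged; the other step, a 2.6-fold lower number from compound 1 to compound 3 (0.41 log units; beyond the scatter), concerns a different ring and offers no guidance here. Since one substitution at this position stayed within the scatter, compound 4 is expected to show no step beyond it, estimated as a 1.0-fold lower number from compound 3 to compound 4 (0.01 log units; within the scatter). Compound 4 is accordingly expected to give around 8000 nM in this assay, within a range from 3000 nM to 22000 nM.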

Compound 4, half-maximal inhibitory concentration: 1330 nM
Beside the measured number, compound 4's estimate is 6.0-fold (0.78 log units) above it; measured number outside the range, below it.
By their numbers in this assay, from the lowest: compound 4; then compounds 3, 2 and 1 (each within the scatter of the next, the first and the last beyond it).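

In this assay, the step of a 6.2-fold lower number from compound 3 to compound 4 (0.79 log units; beyond the scatter) shows that this position can move the number beyond the scatter, which the exchange of bromo for methoxy, a 1.3-fold lower number from compound 1 to compound 2 (0.12 log units; within the scatter), did not. The two steps start from compounds that differ elsewhere, with methoxy on the other ring of compound 1 and fluoro on that ring of compound 3, so the response at this position may depend on that partner group. Nothing measured here gives a reason for the step.

Whether this result belongs to trifluoromethyl alone stays open, since a nitrile, an amine or a carboxylic acid at this position is not among the compounds shown. Also open, going by these compounds, is whether trifluoromethyl would give a similar step on compound 1.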